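A few compounds are considered here, and "the series" means these few. Any claim that something is new, unique, unknown or untested is made for them only; others in the source may bear on it.

Measured so far in a functional assay on the whole organism (strain Charles-Foster albino) for inhibition, with Rattus norvegicus as the target, read by paw edema, at a dose of 50 mg/kg by the oral route; a higher number here means more inhibition at the dose given (going by the name of the read-out), a lower number less inhibition:
Compound 1 `COc1ccc(C2SCC(=O)N2n2c(CSc3nnc(-c4ccncc4)o3)nc3ccc(Br)cc3c2=O)cc1`: 35.3%
Compound 2 `O=C1CSC(c2ccc(Cl)cc2)N1n1c(CSc2nnc(-c3ccncc3)o2)nc2ccc(Br)cc2c1=O`: 25.2%
Compound 3 `O=C1CSC(c2ccc(O)cc2)N1n1c(CSc2nnc(-c3ccncc3)o2)nc2ccc(Br)cc2c1=O`: 32.7%

Compound 2 stands lowest of the three numbers in this assay. Its nearest neighbour is compound 3, the step being a number 7.5 percentage points higher from compound 2 to compound 3 (within the scatter), which lies within the scatter; the furthest is compound 1, the step being a number 10.1 percentage points lower from compound 1 to compound 2 (beyond the scatter), beyond the scatter. The third measured step, a number 2.6 percentage points lower from compound 1 to compound 3 (within the scatter), is also within the scatter. All three measured steps exchange the group on the pendant phenyl ring (methoxy, chloro, hydroxy) and leave the rest of the shared core untouched.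

Compound 4 `O=C1CSC(c2ccc(Cl)cc2)N1n1c(CSc2nnc(-c3ccncc3)o2)nc2ccccc2c1=O` differs from compound 2 in one place: hydrogen in place of bromo on an aromatic carbon. Among the compounds with values here, none of the measured steps touches the bromo, so no step bears directly on this change. With nothing to lean on, the expectation is that the change produces no step beyond the scatter, and the estimated step is a number 0.2 percentage points lower from compound 2 to compound 4 (within the scatter), the range spanning a possible small move in either direction. Compound 4 is expected to give 25% in this assay, with a range from 13% to 37%.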

Compound 4, a percentage reported as inhibition, in the whole organism at one dose (the size of the read-out at that dose, not a potency): 34.1%
For compound 4 the middle estimate is 9.1 percentage points below the measured one; the range from low to high includes it.
By their numbers in this assay, from the lowest: compounds 2, 3, 4 and 1 (each within the scatter of the next, the first and the last beyond it).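

In this assay the replacement of bromo by hydrogen, on an aromatic carbon of the six-membered aromatic ring of carbon only that is part of the fused system, gives a number 8.9 percentage points higher from compound 2 to compound 4 (within the scatter) and stays within the scatter. Within the data shown here, this is the first reading at this position, since the earlier steps all exchange groups on the pendant phenyl ring, and it shows that with chloro on that ring the bromo is not needed for inhibition at the dose given to remain measurable; the pair gives no resolved difference between bromo and hydrogen. No measurement in hand offers an explanation for the size of this step.

On these data alone, this rests on a single pair, so it remains open whether hydrogen in place of bromo gives a similar step with methoxy or hydroxy on the pendant phenyl ring. Also open, as far as these compounds go, is whether another group on this aromatic carbon, such as an amine or a carboxylic acid, would give a step beyond the scatter.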